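Methyl to Methoxy on a Second Thiourea Scaffold

The source may report more compounds than this note shows. Statements on the series, on what has been measured and on what is new or still open speak of the compounds shown alone.

Measured so far in a functional assay on HL-60 cells (Homo sapiens) for antiproliferative activity, with a stated time of 24 h; a higher number here means a weaker inhibitor, a lower number a stronger inhibitor:
Compound 1 `Cc1ccccc1C(=O)Nc1sc2c(c1C(N)=O)CCN(C(=S)Nc1ccccc1Cl)C2` gives 20900 nM.
Compound 2 `COc1ccccc1C(=O)Nc1sc2c(c1C(N)=O)CCN(C(=S)Nc1ccccc1Cl)C2` gives 20800 nM.
Compound 3 `Cc1ccccc1NC(=S)N1CCc2c(sc(NC(=O)c3ccccc3C(F)(F)F)c2C(N)=O)C1` gives 25100 nM.

Compound 1 and compound 2 share a core and differ in one place: methoxy in place of methyl on an aromatic carbon. That change left the read-out essentially unchanged, a 1.0-fold lower number from compound 1 to compound 2 (0.00 log units; within the scatter). Compound 3 carries a different arrangement of the same kinds of groups; how its core differs from that of compound 1 is not broken down here. Its value sits close to those of compound 1 and compound 2, and all three lie within the scatter of one another, so no order among them can be claimed.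

Compound 4 `COc1ccccc1NC(=S)N1CCc2c(sc(NC(=O)c3ccccc3C(F)(F)F)c2C(N)=O)C1` is not yet measured. It relates to compound 3 exactly as compound 2 relates to compound 1: methoxy in place of methyl on an aromatic carbon. The place of the change is described in the same words for both pairs, so this is the same change, although one bond further out it reads as (2-methylphenyl)amino to (2-methoxyphenyl)amino here and as a carbonyl-bearing ring in the earlier pair.

Going by the values given here, the expectation for compound 4 rests on the single earlier example, where the step was a 1.0-fold lower number from compound 1 to compound 2 (0.00 log units; within the scatter). An equally flat step is therefore expected, a 1.0-fold lower number from compound 3 to compound 4 (0.00 log units; within the scatter). Compound 4 is estimated at 25000 nM, within a range from 12000 nM to 52000 nM.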

Compound 4, half-maximal inhibitory concentration: > 50000 nM
Compound 4: no number, only a limit; the forecaster's own chance of this, stated with the estimate: 10%; middle value at least 2.0-fold (0.30 log units) away from the limit.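

In this assay, compound 4 gives > 50000 nM, which is a limit of the assay and not a number. Read against its partner, this gives an at least 1.9-fold higher number from compound 3 to compound 4 (0.29 log units; that floor lies within the scatter), so the methoxy group may have weakened the compound on this core, but the size of the step is unknown and the smallest step the limit allows does not stand clear of the usual scatter. Set beside the flat result on the first core, this single pair shows neither that the change carries over unchanged nor that its outcome depends on the core: the same change on two cores in this assay, a 1.0-fold lower number (0.00 log units; within the scatter) from compound 1 to compound 2 and an at least 1.9-fold higher number (0.29 log units; that floor lies within the scatter) from compound 3 to compound 4; the limit leaves it open whether they differ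

What the compounds leave open is how far compound 4 really lies from compound 3, since only an exact value could show whether the two steps truly differ, and with just two pairs no rule for this change can be drawn in this series. Also open, as far as these compounds go, is how another group, such as ethoxy or hydroxy, would behave in place of the methyl on the 2-methylphenyl ring of compound 3, which would show whether any shift is particular to methoxy.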